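Fluoro in place of chloro: what to expect for compound 4

The source may report more compounds than this note shows. Statements on the series, on what has been measured and on what is new or still open speak of the compounds shown alone.

Compound 1 `Cc1cc2c(c(Oc3cccc(NS(=O)(=O)c4ccc(Cl)cc4)c3)n1)C(=O)N(C(C)C)C2=O` is the reference point, and in an ADME assay (liver) for metabolic stability, with Liver microsome (Rattus norvegicus) as the target, using microsomes (a lower number here means slower removal, a higher number faster removal of the compound), compound 1 gives 250 mL.min-1.g-1. Compound 2 `Cc1cc2c(c(Oc3cccc(N(C)S(=O)(=O)c4ccc(Cl)cc4)c3)n1)C(=O)N(C(C)C)C2=O` reaches only a limit of the assay, > 400 mL.min-1.g-1. Methyl in place of hydrogen on the sulfonamide nitrogen gives an at least 1.6-fold higher number from compound 1 to compound 2 (0.20 log units; that floor lies within the scatter), but that change lies elsewhere in the molecule and offers little guidance here. Compound 3 `Cc1cc2c(c(Oc3cc(NS(=O)(=O)c4ccc(Cl)cc4)ccc3Cl)n1)C(=O)N(C(C)C)C2=O` has the lowest number of the three, 29 mL.min-1.g-1. Chloro in place of hydrogen on an aromatic carbon gives an 8.6-fold lower number from compound 1 to compound 3 (0.94 log units; beyond the scatter).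

Compound 4 `Cc1cc2c(c(Oc3cc(NS(=O)(=O)c4ccc(Cl)cc4)ccc3F)n1)C(=O)N(C(C)C)C2=O` differs from compound 3 in one place: fluoro in place of chloro on an aromatic carbon. This is fluoro in place of chloro on an aromatic carbon, ortho to a large group and para to a ((4-chlorophenyl)sulfonyl)amino group. Within the data shown here, no fluoro compound has been measured yet, so the best guide is the step that put chloro on this same carbon, an 8.6-fold lower number from compound 1 to compound 3 (0.94 log units; beyond the scatter). Compound 4 is expected to keep part of that drop and to land between compound 3 and compound 1. The expected change in this assay is a 2.4-fold higher number from compound 3 to compound 4 (0.38 log units; beyond the scatter), a modest move towards faster removal. Compound 4 is estimated at 70 mL.min-1.g-1, with an expected range of 30 mL.min-1.g-1 to 170 mL.min-1.g-1.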

Compound 4, intrinsic clearance in microsomes: 84 mL.min-1.g-1
Estimate against measurement, compound 4: 1.2-fold (0.08 log units) below; measured number inside the range.
By their numbers in this assay, from the lowest: compound 3; then compound 4; then compound 1. At a limit, above all of these: compound 2.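

In this assay, the identity of the halogen on this carbon matters, not just the presence of one: fluoro in place of chloro gives (a 2.9-fold higher number from compound 3 to compound 4 (0.46 log units; beyond the scatter)), so part of the drop seen with chloro is lost. Fluoro still keeps a clear advantage over hydrogen at the same place, ortho to a large group and para to a ((4-chlorophenyl)sulfonyl)amino group (a 3.0-fold lower number from compound 1 to compound 4 (0.47 log units; beyond the scatter)), and these two steps are close in size, which puts compound 4 about midway between compound 1 and compound 3 on a ratio scale. Nothing shown here accounts for the difference between the two halogens.

From the compounds shown here alone, with only hydrogen, fluoro and chloro at this carbon, it remains open whether a bromo, methyl or nitrile group there would give a number lower still than chloro does. Also open, going by these compounds, is whether a halogen on this carbon would bring down the number of compound 2, whose > 400 mL.min-1.g-1 is a limit of the assay rather than a number.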